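Carbamate to cyclopropyl urea on the shared core

This account rests on a few compounds, and the source may have more. Where it says the series, first, only, none or still open, it means among the compounds named here.

Measured so far:
- compound 1, `COc1ccc([N+](=O)[O-])cc1CSc1nc2cc(NC(=O)NC(C)(C)C)ccc2n1Cc1ccccn1`: 43 nM
- compound 2, `COc1ccc([N+](=O)[O-])cc1CSc1nc2cc(NC(=O)OC(C)(C)C)ccc2n1C(C)C`: 880 nM

Two compounds carry numbers in an assay on isolated protein for inhibition of Gonadotropin-releasing hormone receptor (Homo sapiens); on this read-out higher numbers stand for weaker inhibition and lower numbers for stronger inhibition. Compound 1 gives 43 nM in this assay, and compound 2 gives 880 nM, the higher of the two numbers, with the gap to compound 1 beyond the usual scatter. The pair differs in two places at once, the urea against the carbamate and the pyridylmethyl against the isopropyl on the core, so no single-change step can be read from it; only the two values themselves stand.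

Compound 3, `COc1ccc([N+](=O)[O-])cc1CSc1nc2cc(NC(=O)NC3CC3)ccc2n1C(C)C`, follows from compound 2 by a single change: cyclopropylamino in place of tert-butoxy on a carbonyl carbon. It keeps the isopropyl of compound 2 and takes up a urea, as compound 1 has, though with cyclopropylamino rather than tert-butylamino. Within the data shown here, with no measured one-place step to lean on, the expectation rests on the lower number of compound 1 carrying a urea, 43 nM, against the higher number of the carbamate in compound 2. On that basis the step of a 4.9-fold lower number from compound 2 to compound 3 (0.69 log units; beyond the scatter) is expected to lower the number beyond the scatter. For compound 3 the estimate in this assay is 180 nM, within a range of 45 nM to 700 nM.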

Compound 3, half-maximal inhibitory concentration: 1900 nM
Compound 3: middle estimate off by 11-fold (1.02 log units), on the low side; the measured number lies above the stated range.
By their numbers in this assay, from the lowest: compound 1; then compound 2; then compound 3.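

Among these compounds, with the isopropyl kept, cyclopropylamino in place of tert-butoxy on a carbonyl carbon gives a 2.2-fold higher number from compound 2 to compound 3 (0.33 log units; beyond the scatter) in this assay, a modest step and the first one-place reading. At this place, then, turning the carbamate of compound 2 into the cyclopropyl urea of compound 3 does not lower the number, even though the change brings in a hydrogen-bond donor and a three-membered ring by count; on the isopropyl-bearing core, having a urea is not enough for a lower number. Nothing available bears on the reason for this step.

Still open, from the compounds shown here alone, is how much of the low number of compound 1 belongs to its tert-butylamino and how much to its pyridylmethyl, since tert-butylamino on the isopropyl-bearing core, or pyridylmethyl on the carbamate or on the cyclopropyl urea, would separate the two places. Also open, going by these compounds, is whether an open-chain group at the same carbonyl carbon, such as isopropylamino or dimethylamino, reads closer to tert-butoxy or to cyclopropylamino.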